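The compounds below may be only part of what the source reports. "The series", "measured", "known", "first", "only" and "open" are said of these compounds alone.

Compound 1 `O=C(c1c[nH]c(=O)c2ccccc12)N1CCN(C(=O)c2ccc(Br)cc2)[C@@H](c2ccc(Cl)cc2)C1` gives 11 ug/mL
Compound 2 `O=C(c1cc(-c2cccc(C(F)(F)F)c2)c(=O)n(-c2ccccc2)c1)N1CCN(C(=O)c2ccc(Br)cn2)[C@@H](c2ccc(Cl)cc2)C1` gives 5.9 ug/mL
Compound 3 `N#Cc1cccc(-c2cc(C(=O)N3CCN(C(=O)c4ccc(Br)cn4)[C@@H](c4ccc(Cl)cc4)C3)c[nH]c2=O)c1` gives 2.4 ug/mL

In a physicochemical assay for solubility, at pH 6.8 (a higher number here means a more soluble compound, a lower number a less soluble compound), compound 1 at 11 ug/mL lies within the scatter of compound 2 and beyond the scatter above compound 3 in this small set. The next compound to be measured, compound 4 `O=C(c1ccnc2ccccc12)N1CCN(C(=O)c2ccc(Br)cc2)[C@@H](c2ccc(Cl)cc2)C1`, keeps the rest of compound 1 and changes one group: a group of 10 heavy atoms (9 carbon, 1 nitrogen; one six-membered aromatic ring of carbon only, one six-membered aromatic ring with 1 hetero atom) in place of a group of 11 heavy atoms (9 carbon, 1 nitrogen, 1 oxygen; one six-membered aromatic ring of carbon only, one six-membered aromatic ring with 1 hetero atom), on a carbonyl carbon. The group that enters is quinolin-4-yl, on a carbonyl carbon whose other neighbour is an amide-type nitrogen in a ring. Among the compounds with values here, no two measured compounds differ in one place, so the data offer no direct guide to the size of this step. A modest rise in this assay is expected, although a result within the scatter of compound 1 would be no surprise. The expected change, a 1.8-fold higher number from compound 1 to compound 4 (0.26 log units; within the scatter), is only an estimate. Compound 4 is estimated at 20 ug/mL, with an expected range from 6 ug/mL to 60 ug/mL until the measurement is in.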

Compound 4, solubility: 3.2 ug/mL
Compound 4: the middle estimate sits 6.3-fold (0.80 log units) above what was measured, and the stated range ends above it.
By their numbers in this assay, from the lowest: compounds 3, 4, 2 and 1 (each within the scatter of the next, the first and the last beyond it).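

In this assay, within the data shown here, putting quinolin-4-yl in place of the earlier group on the carbonyl carbon gives a 3.4-fold lower number from compound 1 to compound 4 (0.54 log units; beyond the scatter), the first step in this set that changes one place only. The printed step lies beyond the scatter, so with the rest of compound 1 kept, this place is not indifferent to the exchange, even though the two groups have the same ring types and differ by the oxygen, the double bond outside the aromatic rings and the hydrogen-bond donor of the group that leaves. No measurement here bears on which of these differences accounts for the lower number.

The compounds shown leave open whether a step of this size would recur with the other parts of the molecule changed. They also leave open how this assay would read with an amine or a carboxylic acid at this place on the carbonyl carbon.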